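The source may report more compounds than this note shows. Statements on the series, on what has been measured and on what is new or still open speak of the compounds shown alone.

Compound 1 `COc1ccc2c(=O)c(/C=C/C(=O)NCc3ccccc3)coc2c1` gives 11800 nM in a functional assay on A549 cells (Homo sapiens) for inhibition, read by MTT assay, with a stated time of 48 h; on this read-out lower numbers stand for stronger inhibition and higher numbers for weaker inhibition. Compound 2 `COc1ccc2c(=O)c(/C=C/C(=O)Nc3ccccc3)coc2c1`, with phenyl in place of benzyl on the amide-type nitrogen, gives 51000 nM in this assay, a 4.3-fold higher number from compound 1 to compound 2 (0.64 log units; beyond the scatter). Compound 3 `COc1ccc2c(=O)c(/C=C/C(=O)NCc3ccc(C)cc3)coc2c1` reaches only a limit of this assay, > 100000 nM. That limit is the limit of > 100000 nM in this assay, at which 1 of the 3 values shown sits. Against compound 1 the step is an at least 8.4-fold higher number from compound 1 to compound 3 (0.92 log units; beyond the scatter), whereas an at least 1.9-fold higher number from compound 2 to compound 3 (0.29 log units; that floor lies within the scatter), so compound 3 stands clearly past compound 1 but cannot be separated from compound 2 on the numbers shown.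

Compound 4 `COc1ccc2c(=O)c(/C=C/C(=O)Nc3ccc(C)cc3)coc2c1` differs from compound 3 by 4-methylphenyl in place of 4-methylbenzyl on an amide-type nitrogen. The measured step that most resembles this change is a 4.3-fold higher number from compound 1 to compound 2 (0.64 log units; beyond the scatter), the same exchange of a phenyl for a benzyl on the amide-type nitrogen, which moved the number upward beyond the scatter. Since compound 3 already sits at a limit, a further upward move would leave compound 4 unresolved by this assay. Compound 4 is therefore expected to show no measurable inhibition, with an estimated 200000 nM and a range from 70000 nM to 600000 nM. The step expected from compound 3 to compound 4 is a step that the limit leaves unreadable from compound 3 to compound 4, most likely again reported only as a limit.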

Compound 4, half-maximal inhibitory concentration: 17500 nM
Compound 4: middle estimate off by 11-fold (1.06 log units), on the high side; the whole stated range lies above it.
By their numbers in this assay, from the lowest: compounds 1 and 4 (each within the scatter of the next); then compound 2. At a limit, above all of these: compound 3.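

In this assay, methyl in place of hydrogen on an aromatic carbon now gives a 2.9-fold lower number from compound 2 to compound 4 (0.46 log units; beyond the scatter), so this change does not raise the number on every amide. Its direction depends on the group that carries it, benzyl or phenyl on the amide-type nitrogen: the same change on two cores in this assay moves the number in opposite ways, and the gap is larger than the scatter allows: the same change on two cores in this assay, an at least 8.4-fold higher number (0.92 log units; beyond the scatter) from compound 1 to compound 3 and a 2.9-fold lower number (0.46 log units; beyond the scatter) from compound 2 to compound 4, at least 24-fold (1.39 log units) apart, beyond the scatter of two such steps The shortened group also behaves differently once the methyl is present, since 4-methylphenyl in place of 4-methylbenzyl gives an at least 5.7-fold lower number from compound 3 to compound 4 (0.75 log units; beyond the scatter), whereas phenyl in place of benzyl raised the number in a 4.3-fold higher number from compound 1 to compound 2 (0.64 log units; beyond the scatter), and the 4-methylphenyl amide cannot be separated from the benzyl amide, with a 1.5-fold higher number from compound 1 to compound 4 (0.17 log units; within the scatter).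

Compound 3 is known only as a limit, > 100000 nM, so the full size of every step that touches it stays unread. As far as these compounds go, whether this reversal extends to a chlorine atom or a carboxylic acid on the aromatic ring, or to a longer chain such as phenethyl on the amide-type nitrogen, remains open.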